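Bromo at the phenyl of a pyrazolopyrimidinone cavernosum activator

The compounds below may be only part of what the source reports. "The series", "measured", "known", "first", "only" and "open" are said of these compounds alone.

Measured so far:
Compound 1, `CC(C)Oc1ccccc1-c1nc2c(cnn2-c2ccccc2)c(=O)[nH]1`, in a functional assay on corpus cavernosum (Rattus norvegicus) for activation (a higher number here means a larger maximal response, a lower number a smaller maximal response), compound 1 gives 130%.
Compound 2, `CCCCOc1ccccc1-c1nc2c(cnn2-c2ccccc2)c(=O)[nH]1`, in this assay compound 2 gives 170%.

Among the compounds with values here, compound 2 stands highest of the two numbers; the only measured step, a number 40 percentage points higher from compound 1 to compound 2 (beyond the scatter), concerns the chain on the oxygen. Compound 3, `CCCCOc1ccccc1-c1nc2c(cnn2-c2ccc(Br)cc2)c(=O)[nH]1`, differs from compound 2 by bromo in place of hydrogen on an aromatic carbon. No measured step touches the phenyl, so nothing shown bears directly on this change, and the expectation is a step of a number 5 percentage points lower from compound 2 to compound 3 (within the scatter), none beyond the scatter. Compound 3 is therefore estimated at 165%, between 130% and 200%.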

Compound 3, largest response reached (Emax), in percent of the reference or control that the assay uses: 160%
For compound 3 the middle estimate is 5 percentage points above the measured one, within the range that was stated.
By their numbers in this assay, from the lowest: compound 1; then compounds 3 and 2 (each within the scatter of the next).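

In this assay the change from phenyl to 4-bromophenyl gives a number 10 percentage points lower from compound 2 to compound 3 (within the scatter), the first step read on this ring, so a bromo para to a large group leaves compound 3 within the scatter of compound 2. Nothing at hand bears on the reason for this result.

On these data alone, whether an amine, a methoxy or a carboxylic acid at this same place would give a similar response stays open. So does whether bromo would give a similar step with the isopropyl chain of compound 1 on the oxygen.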